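A few compounds are considered here, and "the series" means these few. Any claim that something is new, unique, unknown or untested is made for them only; others in the source may bear on it.

Compound 1 `C/C(=C\CC/C(C)=C/CC[C@@H]1[C@@]2(C)CCC(=O)C(C)(C)[C@H]2CC[C@@]1(C)O)CC/C=C(\C)C(=O)OCc1cn(C[C@@H]2O[C@H](n3ccc(=O)[nH]c3=O)C[C@H]2O)nn1` gives 28100 nM in a functional assay on A549 cells (Homo sapiens) for antiproliferative activity, read by MTT assay, with a stated time of 48 h; on this read-out lower numbers stand for stronger inhibition and higher numbers for weaker inhibition.
Compound 2 `C/C(=C\CC/C(C)=C/CC[C@@H]1[C@@]2(C)CCC(=O)C(C)(C)[C@H]2CC[C@@]1(C)O)CC/C=C(\C)C(=O)OCc1cn(-c2cccc(C)c2)nn1` reaches only the limit of this assay, recorded as > 150000 nM.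
Compound 3 `C/C(=C\CC/C(C)=C/CC[C@@H]1[C@@]2(C)CCC(=O)C(C)(C)[C@H]2CC[C@@]1(C)O)CC/C=C(\C)C(=O)OCc1cn(C[C@@H]2O[C@H](n3ccc(=O)[nH]c3=O)[C@H]3OC(C)(C)O[C@H]32)nn1` gives 15300 nM in this assay.

Compound 2 carries the 3-methylphenyl group on the triazole where compounds 1 and 3 carry nucleoside-derived groups, and it differs from both in more than one place, so its standing is read from the values alone. Compound 1 and compound 3 return numbers, whereas compound 2 sits at the limit of > 150000 nM in this assay, at which 1 of the 3 values shown sits; on the numbers shown, compound 2 is the one compound that gives no measurable inhibition. Compound 4 `COc1cccc(-n2cc(COC(=O)/C(C)=C/CC/C(C)=C/CC/C(C)=C/CC[C@@H]3[C@@]4(C)CCC(=O)C(C)(C)[C@H]4CC[C@@]3(C)O)nn2)c1` is the not yet measured partner of compound 2. The change is methoxy in place of methyl on an aromatic carbon, a small exchange on the aromatic ring that keeps the rest of the molecule untouched. With compound 2 already at the limit, the step from compound 2 to compound 4 in this assay is expected to be none beyond the scatter, and the expected step of a number no higher from compound 2 to compound 4 (the limit leaves the size open) is set accordingly. Compound 4 is therefore estimated at 150000 nM, with a range from 50000 nM to 300000 nM, and most likely the measurement will again report only a limit.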

Compound 4, half-maximal inhibitory concentration: > 150000 nM
Compound 4: only a limit was reported; the forecaster's own chance of this, stated with the estimate: 75%; the middle value sits exactly at the limit.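

In this assay compound 4 gives > 150000 nM as a limit and not a number. Compound 2 and compound 4 both stand at a limit, and no step can be read between them: the limit of > 150000 nM in this assay, at which 2 of the 4 values shown sit. The compounds shown leave open how 3-methylphenyl and 3-methoxyphenyl compare, and whether either compound gives measurable inhibition at any concentration.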